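Methyl on the amide nitrogen: compound 2 to compound 3

This account rests on a few compounds, and the source may have more. Where it says the series, first, only, none or still open, it means among the compounds named here.

Measured in a functional assay on HeLa cells (Homo sapiens) for antiproliferative activity, read by CCK-8 assay, with a stated time of 72 h; on this read-out lower numbers stand for stronger inhibition and higher numbers for weaker inhibition:
- compound 1 `COc1ccc(-c2cncnc2-c2cc(OC)c(OC)c(OC)c2)cc1` gives 1140 nM here
- compound 2 `CNC(=O)c1ccc(-c2cncnc2-c2cc(OC)c(OC)c(OC)c2)cc1` gives 1470 nM here

Compound 2 stands within the scatter of compound 1, its nearest and only neighbour on these numbers. Compound 3 `COc1cc(-c2ncncc2-c2ccc(C(=O)N(C)C)cc2)cc(OC)c1OC` differs from compound 2 by methyl in place of hydrogen on an amide-type nitrogen and so carries methyl in place of hydrogen on an amide-type nitrogen. Among the compounds with values here, the one measured step is a 1.3-fold higher number from compound 1 to compound 2 (0.11 log units; within the scatter) and replaces methoxy with methylcarbamoyl on an aromatic carbon. Within the data shown here, that step concerns the same group, but no measured pair tests this nitrogen directly. Given the size of a 1.3-fold higher number from compound 1 to compound 2 (0.11 log units; within the scatter) as the only guide, no step beyond the scatter is expected in this assay and no direction can be favoured. The estimated change is a 1.0-fold higher number from compound 2 to compound 3 (0.01 log units; within the scatter) and remains uncertain. Compound 3 is expected at 1500 nM with an estimated range from 700 nM to 3200 nM in this read-out.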

Compound 3, half-maximal inhibitory concentration: 790 nM
Estimate against measurement, compound 3: 1.9-fold (0.28 log units) above; measured number inside the range.
By their numbers in this assay, from the lowest: compounds 3, 1 and 2 (each within the scatter of the next).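

In this assay, the second methyl on the amide nitrogen, which turns methylcarbamoyl into dimethylcarbamoyl, gives a 1.9-fold lower number from compound 2 to compound 3 (0.27 log units; within the scatter) and removes the amide hydrogen without a step that can be separated from the scatter. Placing dimethylcarbamoyl directly on the aromatic carbon in place of methoxy gives a 1.4-fold lower number from compound 1 to compound 3 (0.16 log units; within the scatter), so methoxy, methylcarbamoyl and dimethylcarbamoyl at this position cannot yet be told apart on this read-out. No supporting measurement bears on this result.

From the compounds shown here alone, whether the amide nitrogen tolerates more than methyl remains open, for example with a longer chain such as propyl or with a pyrrolidine amide. Going by these compounds, it is also open whether a carboxylic acid or an amine on the same aromatic carbon would give a step beyond the scatter.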